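The source may report more compounds than this note shows. Statements on the series, on what has been measured and on what is new or still open speak of the compounds shown alone.

Measured so far:
- compound 1, `COc1ccc(C(=O)/C=C/c2cc(OC)c(OC)c(OC)c2)c2c1C=CC(C)(C)O2`: 9150 nM
- compound 2, `COc1ccc(C(=O)/C=C/c2ccc3ccccc3c2)c2c1C=CC(C)(C)O2`: 2140 nM
- compound 3, `COc1ccc(C(=O)/C=C/c2ccc(-c3ccccc3)cc2)c2c1C=CC(C)(C)O2`: > 10000 nM

Three chalcones on a shared core have been run in a functional assay on SW-620 cells (Homo sapiens) for antiproliferative activity, read by MTT assay, with a stated time of 24 h; a lower number here means a stronger inhibitor, a higher number a weaker inhibitor. Compound 1 gives 9150 nM and compound 2 gives 2140 nM. For compound 3 this assay returns only a limit, > 10000 nM; it sits at the limit of > 10000 nM in this assay, at which 1 of the 3 values shown sits, so no number is known for it.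

The next compound, compound 4, `COc1ccc(C(=O)/C=C/c2ccc(Cl)cc2)c2c1C=CC(C)(C)O2`, differs from compound 3 in one place: chloro in place of phenyl on an aromatic carbon. Among the compounds with values here, with compound 3 defined only by its limit, no measured step can be drawn for comparison. Because compound 3 stands at the limit of > 10000 nM in this assay, at which 1 of the 3 values shown sits, the step of an at least 2.5-fold lower number from compound 3 to compound 4 (0.39 log units; beyond the scatter) is expected to point toward stronger inhibition, beyond the scatter. Compound 4 is therefore estimated at 4000 nM, within 1500 nM to 12000 nM.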

Compound 4, half-maximal inhibitory concentration: > 10000 nM
Compound 4: no number, only a limit (the forecaster's own chance of this, stated with the estimate: 20%); middle value at least 2.5-fold (0.39 log units) from the limit.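

Within the data shown here, compound 3 and compound 4 are both limits and not numbers, so no step between them can be read: the limit of > 10000 nM in this assay, at which 2 of the 4 values shown sit. Going by these compounds, how far chloro in place of phenyl on an aromatic carbon moves the value stays open.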